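Compound 3 to compound 4: diethylamino for pyrrolidin-1-yl

The source may hold more compounds than are shown below. What is called first, only, known or untested is meant among the compounds shown, and "the series" means these compounds.

In an ADME assay on L6 cells (Rattus norvegicus) for cytotoxicity, read by resazurin assay, with a stated time of 72 h (a lower number here means a stronger inhibitor, a higher number a weaker inhibitor), compound 1 (`CN(C)C12CC(c3ccccc3)C(CN(C(=O)CN3CCCCC3)C1)C(c1ccccc1)C2`) gives 12100 nM, compound 2 (`CCN(CC)CCC(=O)N1CC2C(c3ccccc3)CC(N(C)C)(CC2c2ccccc2)C1`) gives 15400 nM and compound 3 (`CN(C)C12CC(c3ccccc3)C(CN(CCCN3CCCC3)C1)C(c1ccccc1)C2`) gives 1550 nM. Compound 3 has the lowest number of the three, as shown by a 7.8-fold lower number from compound 1 to compound 3 (0.89 log units; beyond the scatter) and a 9.9-fold lower number from compound 2 to compound 3 (1.00 log units; beyond the scatter). Both steps lie beyond the scatter, and both replace a carbonyl-bearing group with 3-(pyrrolidin-1-yl)propyl on the amine nitrogen in a ring.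

Compound 4 (`CCN(CC)CCCN1CC2C(c3ccccc3)CC(N(C)C)(CC2c2ccccc2)C1`) changes only the terminal amine of compound 3: diethylamino in place of pyrrolidin-1-yl on a saturated chain carbon, three bonds along the chain from an amine nitrogen in a ring. This is 3-(diethylamino)propyl in place of 3-(pyrrolidin-1-yl)propyl. Going by the values given here, no measured pair makes this exact exchange. Among the compounds with values here, the nearest precedent is a 1.3-fold higher number from compound 1 to compound 2 (0.10 log units; within the scatter), within the scatter, where (diethylamino)methyl stands in place of piperidin-1-yl. That pair carries a carbonyl, so it is only indirect support. The larger steps to compound 3 do not isolate the terminal amine.

The estimated change is a 1.2-fold higher number from compound 3 to compound 4 (0.06 log units; within the scatter), and no step beyond the scatter is expected. For compound 4 the estimate is 1800 nM, with an expected range of 800 nM to 4000 nM.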

Compound 4, half-maximal inhibitory concentration: 3270 nM
Beside the measured number, compound 4's estimate is 1.8-fold (0.26 log units) below it; low and high end bracket the measured number.
By their numbers in this assay, from the lowest: compound 3; then compound 4; then compounds 1 and 2 (each within the scatter of the next).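

In this assay, going by these compounds alone, the terminal amine is isolated for the first time: a 2.1-fold higher number from compound 3 to compound 4 (0.32 log units; beyond the scatter), a modest step beyond the scatter, so on a saturated chain carbon, three bonds along the chain from an amine nitrogen in a ring, the open diethylamino group and the pyrrolidin-1-yl ring are not interchangeable. With diethylamino at the chain end, the carbonyl-free chain still gives a 4.7-fold lower number from compound 2 to compound 4 (0.67 log units; beyond the scatter) and a 3.7-fold lower number from compound 1 to compound 4 (0.57 log units; beyond the scatter), so the lower numbers seen with the 3-(pyrrolidin-1-yl)propyl chain are not confined to that terminal ring. No measured evidence accounts for the step at the terminal amine.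

The compounds shown leave open how a dimethylamino group or a morpholine ring at the chain end would compare. Going by these compounds, whether a longer chain carrying either terminal amine would shift the number also remains open.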